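Phenyl for pyridin-3-yl in a low-toxicity series

The compounds below may be only part of what the source reports. "The series", "measured", "known", "first", "only" and "open" are said of these compounds alone.

Measured in an ADME assay on BJ cells (Homo sapiens) for cytotoxicity, with a stated time of 72 h (on this read-out higher numbers stand for an effect only at larger amounts of compound and lower numbers for an effect already at smaller amounts), all as limits:
- compound 1 `Nc1nc(-c2ccccc2)nn1-c1ncnc2cc(Cl)ccc12`: > 50000 nM
- compound 2 `Nc1nc(-c2ccc(Cl)cc2)nn1-c1ncnc2cc(Cl)ccc12`: > 47000 nM
- compound 3 `COc1cc2ncnc(-n3nc(-c4cccnc4)nc3N)c2cc1OC`: > 71000 nM

None of these three compounds has reached a true half-maximal value in this assay. Compound 3 gives only a limit, > 71000 nM, and the same holds for the other two, so its rank among them cannot be read.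

Compound 4 `COc1cc2ncnc(-n3nc(-c4ccccc4)nc3N)c2cc1OC` carries phenyl in place of pyridin-3-yl on an aromatic carbon.

Among the compounds with values here, no measured step makes this exact swap. The nearest evidence is a step that the two limits leave unreadable from compound 1 to compound 2, which is a chloro in place of hydrogen on an aromatic carbon, and its size cannot be read. Compound 1 also bears phenyl, on a different core, and it too gives only a limit, > 50000 nM.

No step beyond the usual scatter is therefore expected, and no direction is favoured. The expected change is an at least 1.1-fold lower number from compound 3 to compound 4 (0.07 log units; that floor lies within the scatter). Compound 4 is estimated at 60000 nM, with an expected range from 20000 nM to 100000 nM, and it will most likely be reported as a limit again.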

Compound 4, half-maximal effective concentration: > 50000 nM
Compound 4: no number, only a limit; the forecaster's own chance of this, stated with the estimate: 80%; the middle value is on the limit's open side.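

Compound 3 and compound 4 each give only a limit in this assay, and the step of phenyl in place of pyridin-3-yl cannot be read. The compounds shown leave open the concentration at which any of them reaches a half-maximal effect, and whether this swap changes that concentration at all.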